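A few compounds are considered here, and "the series" means these few. Any claim that something is new, unique, unknown or untested is made for them only; others in the source may bear on it.

Compound 1 `Cc1cc(C#N)cc(C)c1Oc1nc(Nc2ccc(C#N)cc2)ncc1/C=C/C(=O)NC1CC1` and compound 2 `Cc1cc(C#N)cc(C)c1Oc1nc(Nc2ccc(C#N)cc2)ncc1/C=C/C(=O)NC1CCN(C(=O)C(F)(F)F)CC1` share one core and differ only at the amide-type nitrogen. In an ADME assay on TZM cells (Homo sapiens) for cytotoxicity, with a stated time of 1 days (a higher number here means that more compound is tolerated, a lower number that less compound is tolerated), compound 1 gives > 221 nM, which is a limit of the assay and not a number, namely (the limit of > 221 nM in this assay, at which 1 of the 2 values shown sits). In this assay compound 2 gives > 170 nM, likewise a limit, namely (the limit of > 170 nM in this assay, at which 1 of the 2 values shown sits). The step that the two limits leave unreadable from compound 1 to compound 2 therefore cannot be read, since both ends sit at limits. Compound 3 `Cc1cc(C#N)cc(C)c1Oc1nc(Nc2ccc(C#N)cc2)ncc1/C=C/C(=O)NCCN1CCN(S(C)(=O)=O)CC1` carries 2-(4-(methylsulfonyl)piperazin-1-yl)ethyl in place of 1-((trifluoromethyl)carbonyl)piperidin-4-yl on an amide-type nitrogen. Within the data shown here, the only measured step that bears on a change at this nitrogen is the one from compound 1 to compound 2, and its size is not readable, so the series gives no measured step size to carry over. For compound 3 the step that the limit leaves unreadable from compound 2 to compound 3 in this assay is expected to be no larger than the scatter, and most likely the assay again reports only a limit. The estimate for compound 3 in this assay is 200 nM, within 100 nM to 1000 nM.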

Compound 3, half-maximal cytotoxic concentration: > 166 nM
Compound 3 ended at the assay's limit; the forecaster's own chance of this, stated with the estimate: 80%; the middle value does not contradict the limit.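

In this assay compound 3 gives > 166 nM, a limit and not a number. Compound 1 and compound 2 also stand at limits, so no step among these three compounds can be read. The compounds shown leave open whether the groups on the amide-type nitrogen differ at all in this assay.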